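Swapping Phenyl for Styryl on the Shared Core

The source may report more compounds than this note shows. Statements on the series, on what has been measured and on what is new or still open speak of the compounds shown alone.

Compound 1, `CC(=O)c1cc(-c2ccccc2)cc2cc(-c3ccccc3)[nH]c12`: in a functional assay on MCF7 cells (Homo sapiens) for cytotoxicity, read by MTT assay, with a stated time of 2 days (on this read-out lower numbers stand for higher toxicity in this test and higher numbers for lower toxicity in this test), compound 1 gives only a limit, > 100000 nM.
Compound 2, `CC(=O)c1cc(-c2ccccc2)cc2cc(-c3ccc(F)cc3)[nH]c12`: in this assay compound 2 likewise gives only a limit, > 100000 nM.

Compound 2 thus stands at a limit and not at a number. The step that the two limits leave unreadable from compound 1 to compound 2 cannot be read because both values sit at the limit of > 100000 nM in this assay, at which 2 of the 2 values shown sit. Compound 3, `CC(=O)c1cc(/C=C/c2ccccc2)cc2cc(-c3ccc(F)cc3)[nH]c12`, differs from compound 2 by 2-phenylethenyl in place of phenyl on an aromatic carbon. No measured step bears on this change, and the one step shown is unreadable. Compound 3 is therefore expected to remain near the same limit, the step of a number no higher from compound 2 to compound 3 (the limit leaves the size open) being expected to be small. The estimate for compound 3 is 100000 nM, within 20000 nM to 300000 nM.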

Compound 3, concentration lethal to 50% of the cells: > 100000 nM
Compound 3 was reported as a limit; the forecaster's own chance of this, stated with the estimate: 65%; the middle value lies on the limit itself.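

Among these compounds, compound 3 gives > 100000 nM as a limit and not a number, so no step from compound 2 can be read: the limit of > 100000 nM in this assay, at which 3 of the 3 values shown sit.

From the compounds shown here alone, whether any change on the shared core brings the toxicity in this assay to a readable number stays open.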